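Aryl swap on the tetrazole arm: compound 3 to compound 4

The compounds below may be only part of what the source reports. "The series", "measured", "known", "first", "only" and "open" are said of these compounds alone.

In an assay on HEK293 cells for activation of Kir3.1/Kir3.2 (Homo sapiens), read by thallium flux (a lower number here means that less compound is needed, a higher number that more compound is needed for the effect), compound 3 `Cc1cc(NC(=O)Cn2nnc(-c3cc(Cl)cc(Cl)c3)n2)n(C2CCCCC2)n1` gives 980 nM. Among the measured compounds shown here, only one other number exists in this assay: compound 1 `Cc1cc(NC(=S)Cn2nnc(-c3ccccc3)n2)n(C2CCCCC2)n1` gives 623 nM, which sits within the scatter of the number for compound 3, so the two do not separate. Compound 2 `O=C(Cn1nnc(-c2ccccc2)n1)Nc1cc(C2(C(F)(F)F)CC2)nn1C1CCCCC1` is reported in this assay as "not active" (no number reported), with no number attached. Compound 4 `Cc1ccc(-c2nnn(CC(=O)Nc3cc(C)nn3C3CCCCC3)n2)cc1` is not yet measured. It differs from compound 3 in one place: 4-methylphenyl in place of 3,5-dichlorophenyl on an aromatic carbon. For the measured compounds named here, no step between two measured compounds covers this change. The unsubstituted phenyl of compound 1 and the 3,5-dichlorophenyl of compound 3 gave numbers within the scatter of each other, and nothing in the data points to a shift beyond the scatter in either direction for this aryl group. For compound 4 the expected number in this assay is 900 nM, with a range from 300 nM to 3000 nM. The step this estimate implies, a 1.1-fold lower number from compound 3 to compound 4 (0.04 log units; within the scatter), is expected to remain within the scatter.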

Compound 4, half-maximal effective concentration: 111 nM
Beside the measured number, compound 4's estimate is 8.1-fold (0.91 log units) above it; measured number outside the range, below it.
By their numbers in this assay, from the lowest: compound 4; then compounds 1 and 3 (each within the scatter of the next).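

In this assay, the aryl group on the aromatic carbon of the five-membered aromatic ring with 4 nitrogen proves able to move the number: an 8.8-fold lower number from compound 3 to compound 4 (0.95 log units; beyond the scatter) is beyond the scatter, with 4-methylphenyl in place of 3,5-dichlorophenyl. Both groups hold one six-membered aromatic ring of carbon only, with no hydrogen-bond donors or acceptors and no net charge, so these counts do not separate the pair, and compound 1 differs from compound 3 in more than one place and could not isolate this change. No measurement available here accounts for the shift.

Among the compounds shown here, the single step does not separate the loss of the two chlorines from the gain of the methyl or from the change in substitution pattern. As far as these compounds go, a 4-chlorophenyl or a 3,5-dimethylphenyl group on the same core would address this, and whether 4-methoxyphenyl behaves like 4-methylphenyl remains open.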